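Aryl sulfonyl variation: from compound 2 to compound 3

A few compounds are considered here, and "the series" means these few. Any claim that something is new, unique, unknown or untested is made for them only; others in the source may bear on it.

Measured so far:
compound 1, `CC(C)Cc1cc(CNS(=O)(=O)c2cccc(Cl)c2)nn1-c1ccccc1`, 10900 nM
compound 2, `CC(C)Cc1cc(CNS(=O)(=O)c2cccc3ccccc23)nn1-c1ccccc1`, 2430 nM

Both numbers come from a functional assay on HeLa cells for antagonist activity at 5-hydroxytryptamine receptor 6 (Homo sapiens), read by HTRF and cAMP accumulation, with stated times of 10 min and 30 min; on this read-out higher numbers stand for weaker inhibition and lower numbers for stronger inhibition. Going by the values given here, compound 2 stands at the lowest number of the two; the only other compound, compound 1, gives a higher number, and the step of a 4.5-fold lower number from compound 1 to compound 2 (0.65 log units; beyond the scatter) lies beyond the scatter. Compound 3, `CC(C)Cc1cc(CNS(=O)(=O)c2ccc3ccccc3c2)nn1-c1ccccc1`, differs from compound 2 in one place: naphthalen-2-yl in place of naphthalen-1-yl on a sulfonyl sulfur.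

Among the compounds with values here, the one measured step, a 4.5-fold lower number from compound 1 to compound 2 (0.65 log units; beyond the scatter), changed the aryl group on the sulfonyl sulfur from 3-chlorophenyl to naphthalen-1-yl; it bears on the present step only in showing that this position responds to change. Nothing measured compares naphthalen-1-yl with naphthalen-2-yl on the sulfonyl sulfur, and the two groups have the same atoms, joined differently. The expectation for compound 3 in this assay is therefore a step of a 1.0-fold higher number from compound 2 to compound 3 (0.01 log units; within the scatter), that is, no change beyond the scatter, with a wide range on either side. Compound 3 is estimated at 2500 nM, between 800 nM and 8000 nM.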

Compound 3, half-maximal inhibitory concentration: 3300 nM
The estimate for compound 3 lay 1.3-fold (0.12 log units) below the measured number; the range from low to high includes it.
By their numbers in this assay, from the lowest: compounds 2 and 3 (each within the scatter of the next); then compound 1.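

In this assay, naphthalen-2-yl in place of naphthalen-1-yl on the sulfonyl sulfur gives a 1.4-fold higher number from compound 2 to compound 3 (0.13 log units; within the scatter), so the two ways of joining the same atoms cannot be told apart at this position. Against 3-chlorophenyl, the new group gives a 3.3-fold lower number from compound 1 to compound 3 (0.52 log units; beyond the scatter), and together with a 4.5-fold lower number from compound 1 to compound 2 (0.65 log units; beyond the scatter) this shows that the lower number does not depend on one particular attachment of the two naphthalenyl groups, although these three compounds are a narrow basis and none of them goes against this reading. No supporting data bear on why the two naphthalenyl groups read alike.

The compounds shown leave open whether a quinoline or an aryl ring carrying an amine, placed on the sulfonyl sulfur, would lie closer to the naphthalenyl compounds or to compound 1. They also leave open whether a carboxylic acid or a longer chain elsewhere on the shared core would change how this position responds to aryl variation.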